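This account rests on a few compounds, and the source may have more. Where it says the series, first, only, none or still open, it means among the compounds named here.

For the measured compounds named here, in a functional assay on K562 cells (Homo sapiens) for cytotoxicity, read by MTT assay, with a stated time of 48 h (a lower number here means a stronger inhibitor, a higher number a weaker inhibitor), compound 1 (`COC(=O)/C=C/c1ccc2c(c1)C(=O)C(=O)N2Cc1ccc(OC)cc1`) gives 3 nM and holds the lower of the two numbers so far. Compound 2 (`COC(=O)/C=C/c1ccc2c(c1)C(=O)C(=O)N2C`) stands at 340 nM there. This large step (a 110-fold higher number from compound 1 to compound 2 (2.05 log units; beyond the scatter)) replaces the whole 4-methoxyphenyl with hydrogen. Going by the values given here, compound 3 (`COC(=O)/C=C/c1ccc2c(c1)C(=O)C(=O)N2Cc1ccc(C(F)(F)F)cc1`) keeps that ring and changes only one group on it (trifluoromethyl in place of methoxy on an aromatic carbon), with trifluoromethyl in place of methoxy on an aromatic carbon. Among the compounds with values here, no measured step makes this swap, so the large step is only a loose upper guide. A much smaller rise in the number is expected (a 2.7-fold higher number from compound 1 to compound 3 (0.43 log units; beyond the scatter)). Compound 3 is therefore estimated at 8 nM (2 nM to 50 nM).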

Compound 3, half-maximal inhibitory concentration: 40 nM
The estimate for compound 3 lay 5.0-fold (0.70 log units) below the measured number; measured number inside the range.
By their numbers in this assay, from the lowest: compound 1; then compound 3; then compound 2.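

For the compounds shown here, with the ring kept, the single group on its aromatic carbon still matters: in this assay, trifluoromethyl in place of methoxy gives a 13-fold higher number from compound 1 to compound 3 (1.12 log units; beyond the scatter). The number therefore depends on what that ring carries, not only on whether the ring is present. Even so, compound 3 stands at 40 nM and compound 2 at 340 nM, so this ring with trifluoromethyl still goes with a lower number than the hydrogen swap gave.

No supporting measurement explains the change. From the compounds shown here alone, whether a chlorine, a hydroxyl or an amine on the same aromatic carbon would fall nearer compound 1 or compound 3 remains open.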